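Enlarging the amine on the side chain: compound 2 to compound 3

The source may hold more compounds than are shown below. What is called first, only, known or untested is meant among the compounds shown, and "the series" means these compounds.

Two compounds of this set share a core and differ only in the amine at the end of the side chain. Compound 1 `COc1cc2c(Nc3ccc(C#N)cc3)ncnc2cc1OCCCN(C)C` carries a dimethylamino group and gives 45000 nM in a functional assay on MCF7 cells (Homo sapiens) for antiproliferative activity, read by MTT assay, with a stated time of 72 h; a higher number here means a weaker inhibitor, a lower number a stronger inhibitor. Compound 2 `CCN(CC)CCCOc1cc2ncnc(Nc3ccc(C#N)cc3)c2cc1OC` carries a diethylamino group instead; in this assay compound 2 reaches only the limit of the measurement, > 100000 nM, so no number is known for it. The step of an at least 2.2-fold higher number from compound 1 to compound 2 (0.34 log units; beyond the scatter) therefore shows that the larger amine goes with weaker activity, as far as the limit allows a judgement (the limit of > 100000 nM in this assay, at which 1 of the 2 values shown sits).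

Compound 3 `COc1cc2c(Nc3ccc(C#N)cc3)ncnc2cc1OCCCN(C)Cc1ccccc1` takes this one step further: benzyl(methyl)amino in place of diethylamino on a saturated chain carbon, three bonds along the chain from an oxygen on an aromatic ring. Within the data shown here, only the single step from compound 1 to compound 2 bears on this change, and it pointed toward weaker inhibition with a larger amine. The expectation for compound 3 is therefore that it stays at or near the limit, with the step of a number no higher from compound 2 to compound 3 (the limit leaves the size open) expected to be small. The estimated value for compound 3 in this assay is 100000 nM, within a range from 30000 nM to 300000 nM.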

Compound 3, half-maximal inhibitory concentration: > 100000 nM
Compound 3: only a limit was reported; the forecaster's own chance of this, stated with the estimate: 60%; the middle value lies on the limit itself.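

Compound 3 shows that the move away from dimethylamino is not confined to diethylamino: a benzyl(methyl)amino group, which brings in a six-membered aromatic ring, also goes with weaker activity in this assay, with an at least 2.2-fold higher number from compound 1 to compound 3 (0.34 log units; beyond the scatter). The step between compound 2 and compound 3 cannot be read, as both values are limits, so nothing orders the diethylamino and benzyl(methyl)amino groups against each other. Among the three compounds, dimethylamino is therefore the only amine with a real number, and both larger amines reach the end of the measurable range: the limit of > 100000 nM in this assay, at which 2 of the 3 values shown sit.

Going by these compounds, whether any amine at this position can do better than compound 1 remains open, for instance methylamino, an unsubstituted amine, or a ring amine such as morpholine or piperidine. Also open, on these data alone, is whether a longer or shorter chain carrying the dimethylamino group would move the value in either direction.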